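A Substituted Benzyl in Place of Phenyl

This account rests on a few compounds, and the source may have more. Where it says the series, first, only, none or still open, it means among the compounds named here.

- Compound 1 `Cc1csc2cc([C@H](C)Nc3ncnc(N)c3C#N)c(Cc3cccc(CN4CCC4)c3)c(=O)n12` gives 954000 nM
- Compound 2 `Cc1csc2cc([C@H](C)Nc3ncnc(N)c3C#N)c(-c3ccccc3)c(=O)n12` gives 77000 nM

Both numbers come from a physicochemical assay for solubility; on this read-out higher numbers stand for higher solubility and lower numbers for lower solubility. Compound 2 holds the lower of the two (77000 nM), and its gap to compound 1 lies beyond the usual scatter of repeated measurements.

The next compound to be tested is compound 3 `CNCc1cccc(Cc2c([C@H](C)Nc3ncnc(N)c3C#N)cc3scc(C)n3c2=O)c1`, which shares its core with compound 2 and differs in one group. The change is 3-((methylamino)methyl)benzyl in place of phenyl on an aromatic carbon, in words 3-((methylamino)methyl)benzyl in place of phenyl on an aromatic carbon.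

For the measured compounds named here, no two measured compounds differ in just one place, so no measured step can be carried over directly. Still, compound 3 resembles compound 1 more closely than compound 2, since both carry a substituted benzyl group where compound 2 has phenyl. Compound 3 is therefore expected to land in the region of compound 1 (954000 nM), though not necessarily at the same number. An upward move beyond the scatter is expected, estimated as an 8.4-fold higher number from compound 2 to compound 3 (0.93 log units; beyond the scatter) here. For compound 3 the estimated value is 650000 nM (expected range 250000 nM to 1400000 nM).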

Compound 3, solubility: > 1000000 nM
Compound 3: no number, only a limit; the forecaster's own chance of this, stated with the estimate: 15%; at least 1.5-fold (0.18 log units) between middle value and limit.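

In this assay compound 3 reads > 1000000 nM, and this is a limit of the assay and not a number: the limit of > 1000000 nM in this assay, at which 1 of the 3 values shown sits.

Placing 3-((methylamino)methyl)benzyl in place of phenyl on this aromatic carbon gives an at least 12-fold higher number from compound 2 to compound 3 (1.11 log units; beyond the scatter), the first direct step measured at this position, and it is large even though its true size remains hidden behind the limit. The other step, methylamino in place of azetidin-1-yl, gives an at least 1.0-fold higher number from compound 1 to compound 3 (0.02 log units; that floor lies within the scatter), so this read-out does not put compound 1 and compound 3 in order, and the two amine-bearing benzyl compounds cannot be told apart here.

The compounds shown leave open how much of the step from phenyl belongs to the benzyl frame and how much to the amine on it, a question that a plain benzyl group in the same place would address. Going by these compounds, it also remains open how a carboxylic acid or a longer chain carrying the amine would read, and any such comparison would need values that fall short of the limit.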